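Swapping the Benzyl Substituent in an Amide Series

The compounds below may be only part of what the source reports. "The series", "measured", "known", "first", "only" and "open" are said of these compounds alone.

Compound 2, with structure `CN(Cc1cccc(Cl)c1)C(=O)c1cc2c(Cc3ccccc3)n[nH]c2cc1O`, was tested in a functional assay on A2780 cells (Homo sapiens) for antiproliferative activity, read by resazurin assay, with a stated time of 72 h (a higher number here means a weaker inhibitor, a lower number a stronger inhibitor), and gives 5300 nM. Its close relative compound 1, with structure `CN(Cc1cccc(F)c1)C(=O)c1cc2c(Cc3ccccc3)n[nH]c2cc1O`, gives 5000 nM in this assay. Within the data shown here, the only measured step between them, a 1.1-fold higher number from compound 1 to compound 2 (0.03 log units; within the scatter), lies within the scatter, so compound 2 stands alongside compound 1 rather than apart from it.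

Compound 3, with structure `CCc1ccc(CN(C)C(=O)c2cc3c(Cc4ccccc4)n[nH]c3cc2O)cc1`, has not yet been measured. The change from compound 2 to compound 3 is 4-ethylphenyl in place of 3-chlorophenyl on a saturated chain carbon bound to an amide-type nitrogen. Among the measured compounds shown here, no measured step covers this kind of change; the one step seen here only replaced one halogen with another at the same place and left the number where it was. Without any step that bears directly on it, the expectation for compound 3 is a small step, a 1.0-fold higher number from compound 2 to compound 3 (0.02 log units; within the scatter), in either direction or none beyond the scatter. Compound 3 is therefore estimated at 5500 nM in this assay, with a range from 2200 nM to 14000 nM.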

Compound 3, half-maximal inhibitory concentration: 9400 nM
Estimate against measurement, compound 3: 1.7-fold (0.23 log units) below; the range from low to high includes it.
By their numbers in this assay, from the lowest: compounds 1, 2 and 3 (each within the scatter of the next).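

Among these compounds, until now the only change at this position was one halogen for another, whereas compound 3 replaces 3-chlorophenyl with 4-ethylphenyl, so both the kind of substituent and the number in its name differ. Even so, this assay shows a 1.8-fold higher number from compound 2 to compound 3 (0.25 log units; within the scatter) and a 1.9-fold higher number from compound 1 to compound 3 (0.27 log units; within the scatter) with both steps within the scatter, so this larger exchange on a saturated chain carbon bound to an amide-type nitrogen does not separate compound 3 from either halogen compound. No supporting measurement is available to explain this result.

Because 3-chlorobenzyl and 4-ethylbenzyl differ in both the substituent and its numbered place on the ring, these compounds cannot show what each of those two differences does alone. It also remains open whether an amine, a carboxylic acid or a longer chain on this ring would move the number beyond the scatter, since the three compounds shown carry only a fluoro, a chloro or an ethyl group there.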